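Extending the phenol oxygen in a cytotoxicity series

The compounds below may be only part of what the source reports. "The series", "measured", "known", "first", "only" and "open" are said of these compounds alone.

Compound 1 `COc1cc(OC)c2c(c1)C(C(O)c1ccc(O)cc1)OC2=O`: > 40000 nM
Compound 2 `COc1ccc(C(O)C2OC(=O)c3c(OC)cc(OC)cc32)cc1`: > 40000 nM

In an ADME assay on RAW264.7 cells (Mus musculus) for cytotoxicity, read by MTT assay, with a stated time of 24 h, in the presence of a further agent that is not named here (on this read-out lower numbers stand for stronger inhibition and higher numbers for weaker inhibition), compound 1 gives > 40000 nM, which is a limit of the assay rather than a number. Compound 2 likewise stops at a limit, > 40000 nM. The step that the two limits leave unreadable from compound 1 to compound 2 is therefore unreadable. Compound 3 `CCOCCOc1ccc(C(O)C2OC(=O)c3c(OC)cc(OC)cc32)cc1` has not been measured; it differs from compound 1 by 2-ethoxyethyl in place of hydrogen on an oxygen on an aromatic ring. For the measured compounds named here, because of the limit of > 40000 nM in this assay, at which 2 of the 2 values shown sit, the one measured step gives no guidance, and a result at the limit remains the likeliest outcome for compound 3. Compound 3 is expected to give 50000 nM, within 20000 nM to 150000 nM. The expected step that the limit leaves unreadable from compound 1 to compound 3 is no change beyond the scatter.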

Compound 3, half-maximal inhibitory concentration: > 40000 nM
Compound 3: a limit, no number; the forecaster's own chance of this, stated with the estimate: 80%; the middle value is on the limit's open side.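

For the compounds shown here, compound 1, compound 2 and compound 3 all stop at a limit of the assay, so no step among them can be read. From the compounds shown here alone, whether any group on this oxygen changes cytotoxicity remains open.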